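A few compounds are considered here, and "the series" means these few. Any claim that something is new, unique, unknown or untested is made for them only; others in the source may bear on it.

Of the compounds shown here, two with a shared core have so far been read in a functional assay on B16 cells (Mus musculus) for antiproliferative activity, read by MTT assay, with a stated time of 24 h; on this read-out lower numbers stand for stronger inhibition and higher numbers for weaker inhibition. Compound 1 `C=CCOc1ccc2c(=O)c(-c3cc(OC)c(OC)cc3OC)coc2c1` gives 5100 nM and compound 2 `COc1cc(OC)c(-c2coc3cc(OCc4ccccc4C)ccc3c2=O)cc1OC` gives 2150 nM, which makes compound 2 the lower of the two numbers. Compound 3 `COc1cc(OC)c(-c2coc3cc(OCc4ccccc4Cl)ccc3c2=O)cc1OC` departs from compound 2 in one place only: chloro in place of methyl on an aromatic carbon with chloro in place of methyl on an aromatic carbon, so that 2-methylbenzyl becomes 2-chlorobenzyl. Going by the values given here, no measured pair tests this exchange directly. Among the compounds with values here, the only measured step is a 2.4-fold lower number from compound 1 to compound 2 (0.38 log units; beyond the scatter) and it accompanied 2-methylphenyl in place of vinyl. That was a change of a whole group, whereas here the aromatic ring stays and a single substituent on it is exchanged. The modest size of that step therefore serves only as a loose ceiling, and in this assay little or no change beyond the scatter is expected, with no firm direction. The expected step is a 1.1-fold lower number from compound 2 to compound 3 (0.03 log units; within the scatter) and it remains an estimate. For compound 3 the estimated value is 2000 nM with an expected range from 900 nM to 4500 nM in this read-out.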

Compound 3, half-maximal inhibitory concentration: 4180 nM
Compound 3: the middle estimate sits 2.1-fold (0.32 log units) below what was measured; the range from low to high includes it.
By their numbers in this assay, from the lowest: compounds 2, 3 and 1 (each within the scatter of the next, the first and the last beyond it).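

In this assay, the exchange of methyl for chloro on an aromatic carbon, ortho to a large group, now has a direct test: it gives a 1.9-fold higher number from compound 2 to compound 3 (0.29 log units; within the scatter), so 2-methylbenzyl and 2-chlorobenzyl cannot be told apart here. The comparison with vinyl also becomes less simple, since 2-methylphenyl in place of vinyl gave a 2.4-fold lower number from compound 1 to compound 2 (0.38 log units; beyond the scatter), whereas 2-chlorophenyl in place of vinyl gives a 1.2-fold lower number from compound 1 to compound 3 (0.09 log units; within the scatter), so an aromatic ring at this place does not by itself separate a compound from compound 1 beyond the scatter. Nothing available offers an explanation for the difference between these two steps.

With only methyl and chloro shown on this aromatic carbon, the compounds leave open how a group such as methoxy, nitrile or trifluoromethyl would read there, and whether a plain unsubstituted benzyl would fall with compound 2 or compound 3. They also leave open how the read-out would respond if an amine, a carboxylic acid or a longer chain took the place of the aromatic ring on the chain bound to the oxygen.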